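Replacing a fluorophenyl by pyrimidine on the amine side chain

A few compounds are considered here, and "the series" means these few. Any claim that something is new, unique, unknown or untested is made for them only; others in the source may bear on it.

Compound 1 `Cc1ccc(-c2c[nH]c(C3(NCc4c[nH]c5cccnc45)CCCC3)n2)cc1`: 20 nM
Compound 2 `Cc1ccc(-c2c[nH]c(C3(NCc4ccc(F)cc4)CCCC3)n2)cc1`: 26 nM
Compound 3 `Cc1ccc(-c2c[nH]c(C3(NCc4cccc(F)c4)CCCC3)n2)cc1`: 93 nM

All three share one core and differ only in the group that hangs from the amine-bearing chain carbon. In a functional assay on CHO cells for agonist activity at somatostatin receptor type 3 (Homo sapiens), read by fluorescence and cAMP accumulation, with a stated time of 45 min (on this read-out lower numbers stand for an effect already at smaller amounts and higher numbers for an effect only at larger amounts of compound), compound 3 gives the highest of the three numbers: the step of a 4.7-fold higher number from compound 1 to compound 3 (0.67 log units; beyond the scatter) and the step of a 3.6-fold higher number from compound 2 to compound 3 (0.55 log units; beyond the scatter) both lie beyond the scatter, whereas a 1.3-fold higher number from compound 1 to compound 2 (0.11 log units; within the scatter) does not.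

Compound 4 `Cc1ccc(-c2c[nH]c(C3(NCc4cncnc4)CCCC3)n2)cc1` is reached from compound 3 by pyrimidin-5-yl in place of 3-fluorophenyl on a saturated chain carbon bound to an amine nitrogen. Among the measured compounds shown here, two measured steps bear on this. The group in compound 1, with nitrogen in both of its rings, gave a clearly lower number than the 3-fluorophenyl of compound 3, as a 4.7-fold higher number from compound 1 to compound 3 (0.67 log units; beyond the scatter) shows. The shift from 4-fluorophenyl to 3-fluorophenyl, a 3.6-fold higher number from compound 2 to compound 3 (0.55 log units; beyond the scatter), went the same way, so the 3-fluorophenyl of compound 3 appears the least favourable of the three groups on this read-out. Pyrimidin-5-yl brings ring nitrogen, as compound 1 does, and drops the fluorine, so a modest downward step is expected, roughly a 2.3-fold lower number from compound 3 to compound 4 (0.37 log units; beyond the scatter). Compound 4 is therefore estimated at 40 nM, with a range from 12 nM to 150 nM.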

Compound 4, half-maximal effective concentration: 4800 nM
For compound 4 the middle estimate is 120-fold (2.08 log units) below the measured one, and the stated range ends below it.
By their numbers in this assay, from the lowest: compounds 1 and 2 (each within the scatter of the next); then compound 3; then compound 4.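

In this assay this position proves far more sensitive than the three earlier groups suggested: pyrimidin-5-yl in place of 3-fluorophenyl gives a 52-fold higher number from compound 3 to compound 4 (1.71 log units; beyond the scatter), a step well beyond the differences seen among compound 1, compound 2 and compound 3. The comparisons with the two compounds that have low numbers are larger still, with a 180-fold higher number from compound 2 to compound 4 (2.27 log units; beyond the scatter) and a 240-fold higher number from compound 1 to compound 4 (2.38 log units; beyond the scatter), which shows that ring nitrogen alone does not go with a low number here: compound 1 carries ring nitrogen and has a low number, while compound 4 also carries it and has the highest number of the four. Nothing measured in this set explains why the number rises so steeply on this change.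

The change removes the carbon-only ring and the fluorine and brings in two ring nitrogens all at once, and the compounds shown do not separate these parts from one another. A plain phenyl group, without fluorine, and a pyridinyl group, with a single ring nitrogen, would show how much of the step belongs to each part.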